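The compounds below may be only part of what the source reports. "The series", "measured", "known", "first", "only" and "open" are said of these compounds alone.

Three compounds were measured in an assay for binding affinity to dual specificity mitogen-activated protein kinase kinase 4 (Homo sapiens), read by KINOMEscan, tested at 100 nM; a higher number here means a weaker effect of the compound at the concentration tested, a lower number a stronger effect:

Compound 1 `CCCS(=O)(=O)Nc1ccc(F)c(C(=O)c2n[nH]c3ncc(-c4ccccc4C)cc23)c1F`: 7%
Compound 2 `CCCS(=O)(=O)Nc1ccc(F)c(C(=O)c2n[nH]c3ncc(-c4ccccc4N)cc23)c1F`: 23%
Compound 3 `CCCS(=O)(=O)Nc1ccc(F)c(C(=O)c2n[nH]c3ncc(-c4cc(Cl)cc(Cl)c4)cc23)c1F`: 73%

Compound 3 gives the highest number of the three, that is the weakest effect, with a number 50 percentage points higher from compound 2 to compound 3 (beyond the scatter) and a number 66 percentage points higher from compound 1 to compound 3 (beyond the scatter) both beyond the scatter. Compound 4 `CCCS(=O)(=O)Nc1ccc(F)c(C(=O)c2n[nH]c3ncc(-c4ccc(S(=O)(=O)NC)cc4)cc23)c1F` differs from it by 4-(methylsulfamoyl)phenyl in place of 3,5-dichlorophenyl on an aromatic carbon. Within the data shown here, no measured step involves the entering group, so the two steps leading to compound 3 are the only guide: both show that exchanging the aryl group at this position moves the number by a large amount. Compound 3 being the weakest of the set, a new aryl group is expected to move the number down, but with wide uncertainty: a step of a number 33 percentage points lower from compound 3 to compound 4 (beyond the scatter) is estimated, giving compound 4 an expected value of 40%, within 10% to 85%.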

Compound 4, a percentage reported as activity, at one concentration (the size of the read-out at that concentration, not a potency): 1.2%
Compound 4: middle estimate off by 38.8 percentage points, on the high side; the whole stated range lies above it.
By their numbers in this assay, from the lowest: compounds 4 and 1 (each within the scatter of the next); then compound 2; then compound 3.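

In this assay, 4-(methylsulfamoyl)phenyl gives a number 71.8 percentage points lower from compound 3 to compound 4 (beyond the scatter) and so shows that an aryl group with more heavy atoms than 3,5-dichlorophenyl can give a strong effect at this position. It also gives a number 21.8 percentage points lower from compound 2 to compound 4 (beyond the scatter) and a number 5.8 percentage points lower from compound 1 to compound 4 (within the scatter) so it joins 2-methylphenyl at the low end of the series. Nothing available explains these differences.

On these data alone, it remains open whether the methylsulfamoyl group itself matters or only where it sits on the ring. Unsubstituted phenyl, or a carboxylic acid on that ring, would help to separate these possibilities.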